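A few compounds are considered here, and "the series" means these few. Any claim that something is new, unique, unknown or untested is made for them only; others in the source may bear on it.

Measured so far:

Compound 1 `Oc1cccc(CNc2cc(Br)cc3[nH]ncc23)c1` — 45%
Compound 2 `CC(=O)Nc1ccc(CNc2cc(Br)cc3[nH]ncc23)cc1` — 48%
Compound 3 `Nc1ccccc1CNc1cc(Br)cc2[nH]ncc12` — 36%

In an assay for inhibition of Indoleamine 2,3-dioxygenase 1 (Homo sapiens), with a stated time of 1 h, tested at 10 uM (a higher number here means more inhibition at the concentration tested (going by the name of the read-out), a lower number less inhibition), compound 1 gives 45%. On the numbers shown it sits between the other two: compound 2, with 48%, is the nearest, and compound 3, with 36%, is the furthest, yet both gaps lie within the usual scatter of such measurements, so the three cannot be told apart. No pair of these compounds differs in one place only, so no single structural step has yet been followed within the set.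

Compound 4 `Nc1cccc(CNc2cc(Br)cc3[nH]ncc23)c1` is the next to be measured. Compared with compound 1 the change is amino in place of hydroxy on an aromatic carbon. With nothing of this kind of exchange seen before among the measured compounds, the step from compound 1 to compound 4 is expected to be no change at the digits printed from compound 1 to compound 4 (within the scatter), that is, no change beyond the scatter. Compound 4 is therefore estimated at 45% in this assay, within a range from 30% to 60%.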

Compound 4, a percentage reported as inhibition, at one concentration (the size of the read-out at that concentration, not a potency): 31%
The estimate for compound 4 lay 14 percentage points above the measured number; the range from low to high includes it.
By their numbers in this assay, from the lowest: compounds 4, 3, 1 and 2 (each within the scatter of the next, the first and the last beyond it).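

Amino in place of hydroxy on an aromatic carbon, meta to a large group, gives a number 14 percentage points lower from compound 1 to compound 4 (beyond the scatter) in this assay, the first single change that can be followed in this set. The two groups have the same counts of heavy atoms, hydrogen-bond donors and acceptors and the same lack of net charge, yet the read-out still separates them, so these counts alone do not settle the outcome at this position. Nothing measured here accounts for the step.

From the compounds shown here alone, whether a methoxy group, a methylamino group or a carboxylic acid at this position would read closer to compound 1 or to compound 4 remains open. So does whether the same exchange would give a similar step elsewhere on this ring, since this is a single pair at one concentration.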